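Swapping methyl for trifluoromethyl beside a cyclopentyl group

The source may hold more compounds than are shown below. What is called first, only, known or untested is meant among the compounds shown, and "the series" means these compounds.

Three related compounds have been measured in a functional assay on MCF7 cells (Homo sapiens) for cytotoxicity, read by MTT assay, with a stated time of 48 h; on this read-out higher numbers stand for weaker inhibition of growth and lower numbers for stronger inhibition of growth. Compound 1 `Cn1c(C(F)(F)F)nc2cc(Cl)c(Cl)cc21` gives 39000 nM, compound 2 `CCn1c(C(F)(F)F)nc2cc(Cl)c(Cl)cc21` gives 72900 nM, and compound 3 `Cc1nc2cc(Cl)c(Cl)cc2n1C1CCCC1` gives 40000 nM. Compound 3 therefore lies within the usual scatter of both others, and these three values cannot be ranked against it.

Compound 4 `FC(F)(F)c1nc2cc(Cl)c(Cl)cc2n1C1CCCC1` has not yet been measured. It differs from compound 3 in one place: trifluoromethyl in place of methyl on an aromatic carbon. In words, this is trifluoromethyl in place of methyl on an aromatic carbon, next to the ring atom that bears a cyclopentyl group.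

Within the data shown here, no measured pair isolates this swap. Among the measured compounds shown here, the only measured step is a 1.9-fold higher number from compound 1 to compound 2 (0.27 log units; within the scatter), which places methyl in place of hydrogen on a saturated chain carbon bound to an aromatic nitrogen. That is a different place, so it bears on the swap only indirectly. Compound 1 and compound 2 already carry trifluoromethyl, and their values stay within the scatter of compound 3. For the measured compounds named here, with a 1.9-fold higher number from compound 1 to compound 2 (0.27 log units; within the scatter) as the only guide, no step beyond the scatter is expected in this assay, in either direction.

The estimated step is a 1.1-fold higher number from compound 3 to compound 4 (0.05 log units; within the scatter). Compound 4 is expected at 45000 nM, with an estimated range of 18000 nM to 110000 nM.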

Compound 4, concentration for 50% growth inhibition: 21000 nM
Beside the measured number, compound 4's estimate is 2.1-fold (0.33 log units) above it, and the stated range covers the measured number.
By their numbers in this assay, from the lowest: compounds 4, 1, 3 and 2 (each within the scatter of the next, the first and the last beyond it).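

In this assay, trifluoromethyl in place of methyl on this aromatic carbon, next to the ring atom that bears a cyclopentyl group, gives a 1.9-fold lower number from compound 3 to compound 4 (0.28 log units; within the scatter), so this first direct reading of the swap shows no change that can be told apart from the usual variation between repeats. Among these compounds, the new compound also gives the first reading of the group on the aromatic nitrogen with trifluoromethyl held constant: cyclopentyl in place of methyl gives a 1.9-fold lower number from compound 1 to compound 4 (0.27 log units; within the scatter), which also cannot be told apart from that variation, whereas cyclopentyl in place of ethyl gives a 3.5-fold lower number from compound 2 to compound 4 (0.54 log units; beyond the scatter), a modest step and the only one of the three that clears it. No measurement here offers an explanation for any of these steps.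

The compounds shown leave open whether a different group on the same aromatic carbon, such as an amine or a carboxylic acid, would shift the number clearly in either direction. They also leave open how a longer chain on the aromatic nitrogen, such as butyl, would compare with ethyl and cyclopentyl.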